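A few compounds are considered here, and "the series" means these few. Any claim that something is new, unique, unknown or untested is made for them only; others in the source may bear on it.

Compounds measured in a functional assay on SW1573 cells (Homo sapiens) for antiproliferative activity, read by sulforhodamine B assay, with a stated time of 48 h; on this read-out higher numbers stand for weaker inhibition of growth and lower numbers for stronger inhibition of growth:

Compound 1, `Cc1ccc(S(=O)(=O)OC[C@H]2O[C@@H](OCc3noc(-c4ccc([N+](=O)[O-])cc4)n3)[C@@H]3OC4(CCCC4)O[C@@H]32)cc1`: > 100000 nM
Compound 2, `COc1cc(-c2nc(CO[C@@H]3O[C@H](CSc4nnc(N)s4)[C@H]4OC5(CCCC5)O[C@@H]34)no2)cc(OC)c1OC`: 38000 nM
Compound 3, `O=[N+]([O-])c1ccc(-c2nc(CO[C@@H]3O[C@H](CSc4ncn[nH]4)[C@H]4OC5(CCCC5)O[C@@H]34)no2)cc1`: 15000 nM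

Compound 1 gives only a limit in this assay, > 100000 nM, not a number. Among the two numbers, compound 3 gives the lowest, at 15000 nM; compound 2, the nearest, sits at 38000 nM, a gap beyond the scatter. Within the data shown here, the one measured step is an at least 6.6-fold lower number from compound 1 to compound 3 (0.82 log units; beyond the scatter), a change at the same position of the shared core as the one studied here, with the limit of > 100000 nM in this assay, at which 1 of the 3 values shown sits, setting its floor.

Compound 4, `Nc1nnc(SC[C@H]2O[C@@H](OCc3noc(-c4ccc([N+](=O)[O-])cc4)n3)[C@@H]3OC4(CCCC4)O[C@@H]32)s1`, has not yet been measured in this assay. It differs from compound 3 in one place: 5-amino-1,3,4-thiadiazol-2-yl in place of 1H-1,2,4-triazol-5-yl on a sulfur. Compound 2 already carries the 5-amino-1,3,4-thiadiazol-2-yl group on a sulfur, together with a different aryl group, and its number lies above that of compound 3 by a gap beyond the scatter. Among the measured compounds shown here, the step from compound 1 to compound 3 shows that this chain position tolerates a large change, yet no measured step isolates the triazolyl-to-thiadiazolyl swap alone. Compound 4 is therefore expected to land near compound 3 or somewhat higher, a step of a 1.7-fold higher number from compound 3 to compound 4 (0.22 log units; within the scatter) that may not exceed the scatter. The estimate for compound 4 in this assay is 25000 nM, within 10000 nM to 60000 nM.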

Compound 4, concentration for 50% growth inhibition: 16000 nM
Compound 4: the middle estimate sits 1.6-fold (0.19 log units) above what was measured; low and high end bracket the measured number.
By their numbers in this assay, from the lowest: compounds 3 and 4 (each within the scatter of the next); then compound 2. At a limit, above all of these: compound 1.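

In this assay, the two rings on the sulfur cannot be told apart when the 4-nitrophenyl group is present: 5-amino-1,3,4-thiadiazol-2-yl in place of 1H-1,2,4-triazol-5-yl gives a 1.1-fold higher number from compound 3 to compound 4 (0.03 log units; within the scatter). Among these compounds, compound 4 also isolates the aryl group, which no earlier pair did: with the sulfanyl group held fixed, 4-nitrophenyl in place of 3,4,5-trimethoxyphenyl gives a 2.4-fold lower number from compound 2 to compound 4 (0.38 log units; beyond the scatter), while (5-amino-1,3,4-thiadiazol-2-yl)sulfanyl in place of ((4-methylphenyl)sulfonyl)oxy gives an at least 6.2-fold lower number from compound 1 to compound 4 (0.79 log units; beyond the scatter), a second lower number from that replacement alongside the one for (1H-1,2,4-triazol-5-yl)sulfanyl. Compound 1 gives a limit rather than a number, so the last step has a floor and no measured size: the limit of > 100000 nM in this assay, at which 1 of the 4 values shown sits.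

As far as these compounds go, whether the two rings on the sulfur also stay within the scatter of each other when 3,4,5-trimethoxyphenyl is the aryl group remains open. Also open, from the compounds shown here alone, is how this assay would read a 4-aminophenyl group in place of 4-nitrophenyl, or a carboxylic acid or a simple amine in place of the sulfanyl groups on the saturated chain carbon.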